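The compounds below may be only part of what the source reports. "The series", "measured", "known", "first", "only" and "open" are said of these compounds alone.

In a physicochemical assay for metabolic stability, read by HPLC and mass spectrometry, in phosphate buffer, at 37 degrees C, at pH 7.4 (a higher number here means that the compound lasts longer, a lower number that the compound disappears faster), compound 1 `CC(C)(O/N=C(\C(=O)N[C@@H]1C(=O)N(S(=O)(=O)O)[C@@H]1CNC(=O)CN)c1csc(N)n1)C(=O)O` gives 149 h. Compound 2 `CC(C)(O/N=C(\C(=O)N[C@@H]1C(=O)N(S(=O)(=O)O)[C@@H]1CN1CCC1=O)c1csc(N)n1)C(=O)O` gives > 1000 h, which is a limit of the assay and not a number. Compound 3 `CC(C)(O/N=C(\C(=O)N[C@@H]1C(=O)N(S(=O)(=O)O)[C@@H]1Cn1ccnn1)c1csc(N)n1)C(=O)O` has yet to be measured. It carries 1H-1,2,3-triazol-1-yl in place of 2-oxoazetidin-1-yl on a saturated chain carbon bound to a saturated ring carbon. For the measured compounds named here, one measured step bears on this place: an at least 6.7-fold higher number from compound 1 to compound 2 (0.82 log units; beyond the scatter), with 2-oxoazetidin-1-yl in place of ((aminomethyl)carbonyl)amino. That step shows that a swap here can move the half-life beyond the scatter, but it involves a different incoming group and gives no direct size for this change. Compound 2 stands at the limit of > 1000 h in this assay, at which 1 of the 2 values shown sits, so only a step to a lower number could be read. A modest fall is expected, and the estimated step is an at least 2.5-fold lower number from compound 2 to compound 3 (0.39 log units; beyond the scatter). For compound 3 the expected half-life is 400 h, with an estimated range from 130 h to 1000 h.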

Compound 3, half-life: 257 h
Estimate against measurement, compound 3: 1.6-fold (0.19 log units) above; measured number inside the range.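

In this assay, the place on a saturated chain carbon bound to a saturated ring carbon now carries a third group, and 1H-1,2,3-triazol-1-yl in place of 2-oxoazetidin-1-yl gives an at least 3.8-fold lower number from compound 2 to compound 3 (0.59 log units; beyond the scatter). The value of compound 2 is a limit of the assay and not a number, so this step gives only a smallest size, not a true one: the limit of > 1000 h in this assay, at which 1 of the 3 values shown sits. The other new step is a 1.7-fold higher number from compound 1 to compound 3 (0.24 log units; within the scatter), so 1H-1,2,3-triazol-1-yl and ((aminomethyl)carbonyl)amino cannot be told apart by half-life, and only 2-oxoazetidin-1-yl stands apart from the other two.

From the compounds shown here alone, the real half-life of compound 2 remains open, as does whether its four-membered ring or its carbonyl goes with the longer half-life. Going by these compounds, it is also open how a plain amine, a carboxylic acid or 2-oxopyrrolidin-1-yl would behave at this place.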